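Replacing 2-aminophenyl with hydroxy on an amide-type nitrogen

This account rests on a few compounds, and the source may have more. Where it says the series, first, only, none or still open, it means among the compounds named here.

In a functional assay on A549 cells (Homo sapiens) for antiproliferative activity, read by CCK-8 assay, with a stated time of 72 h (on this read-out lower numbers stand for stronger inhibition and higher numbers for weaker inhibition), compound 1 (`Nc1ccccc1NC(=O)/C=C/c1ccc(COc2ccccc2)cc1`) gives > 32000 nM, which is a limit and not a number. Its place on the scale is the limit of > 32000 nM in this assay, at which 1 of the 3 values shown sits. Compound 2 (`CC(C)c1ccc(OCc2ccc(C(=O)Nc3ccccc3N)cc2)cc1`) gives 7460 nM and compound 3 (`Nc1ccccc1NC(=O)c1ccc(COc2ccc(F)cc2)cc1`) gives 5370 nM. Among the compounds with values here, the one measured step, a 1.4-fold lower number from compound 2 to compound 3 (0.14 log units; within the scatter), lies elsewhere in the structure and does not bear on the amide-type nitrogen. Compound 4 (`O=C(/C=C/c1ccc(COc2ccccc2)cc1)NO`) carries hydroxy in place of 2-aminophenyl at that nitrogen (hydroxy in place of 2-aminophenyl on an amide-type nitrogen). No measured step sizes this change, so the expectation is tentative. A lower number is expected, near the 5370 nM of compound 3. The expected step is an at least 10-fold lower number from compound 1 to compound 4 (1.02 log units; beyond the scatter). For compound 4 the estimate is 3000 nM, with an expected range of 600 nM to 15000 nM.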

Compound 4, half-maximal inhibitory concentration: 5770 nM
For compound 4 the middle estimate is 1.9-fold (0.28 log units) below the measured one; the measured number falls inside the stated range.
By their numbers in this assay, from the lowest: compounds 3, 4 and 2 (each within the scatter of the next). At a limit, above all of these: compound 1.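

Within the data shown here, on the amide-type nitrogen, hydroxy in place of 2-aminophenyl gives the first measured step at this position: in this assay it is an at least 5.5-fold lower number from compound 1 to compound 4 (0.74 log units; beyond the scatter). On this shared core, then, 2-aminophenyl is not needed at that nitrogen for a measurable number. The true size of the step stays unknown, since the value for compound 1 is a limit: the limit of > 32000 nM in this assay, at which 1 of the 4 values shown sits.

The compounds shown leave open whether the change in number comes from hydroxy itself or from the loss of 2-aminophenyl. A methoxy or a plain amino group on that nitrogen would separate the two.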